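Moving the Pyridine Nitrogen a Second Time

The source may hold more compounds than are shown below. What is called first, only, known or untested is meant among the compounds shown, and "the series" means these compounds.

Measured so far in an assay on L cells for inhibition of Protein-serine O-palmitoleoyltransferase porcupine (Mus musculus), read by reporter gene assay, with a stated time of 24 h; on this read-out lower numbers stand for an effect already at smaller amounts and higher numbers for an effect only at larger amounts of compound:
- compound 1, `O=C(CSc1nc2c(c(=O)n1-c1ccccc1)SCC2)Nc1ccc(-c2ccccn2)cc1`: 4 nM
- compound 2, `O=C(CSc1nc2c(c(=O)n1-c1ccccc1)SCC2)Nc1ccc(-c2ccncc2)cc1`: 3 nM

Going by the values given here, compound 2 holds the lowest of the two numbers measured in this assay, but its only neighbour, compound 1, lies within the scatter of it, so the two cannot be ranked. Compound 3, `O=C(CSc1nc2c(c(=O)n1-c1ccccc1)SCC2)Nc1ccc(-c2cccnc2)cc1`, is not yet measured; compared with compound 2 it carries pyridin-3-yl in place of pyridin-4-yl on an aromatic carbon. Among the compounds with values here, the one measured step that bears on this change is the earlier shift of the same nitrogen within the attached group: a 1.3-fold lower number from compound 1 to compound 2 (0.12 log units; within the scatter). That step stayed within the scatter, so a further shift of that nitrogen is expected to give no step beyond the scatter in this assay, in no particular direction. Compound 3 is therefore expected to come in at 3.5 nM, with a range from 1.5 nM to 9 nM. This amounts to an expected step of a 1.2-fold higher number from compound 2 to compound 3 (0.07 log units; within the scatter).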

Compound 3, half-maximal effective concentration: 0.45 nM
For compound 3 the middle estimate is 7.8-fold (0.89 log units) above the measured one; the whole stated range lies above it.
By their numbers in this assay, from the lowest: compound 3; then compounds 2 and 1 (each within the scatter of the next).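

The position of the nitrogen within this pyridine ring matters in this assay, which the first shift of that atom did not reveal: pyridin-3-yl gives a 6.7-fold lower number from compound 2 to compound 3 (0.82 log units; beyond the scatter) and an 8.9-fold lower number from compound 1 to compound 3 (0.95 log units; beyond the scatter). The change is not a steady trend around the ring, since compound 1 and compound 2 stay within the scatter of each other and only compound 3 stands apart. The groups exchanged have the same counts of atoms, donors and acceptors, so these steps come from a different arrangement of the same atoms at this place.

Nothing available here explains why pyridin-3-yl stands out. Also open, going by these compounds, is how a pyrimidin-5-yl ring, or a pyridin-3-yl ring carrying an amine, would read at this place.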